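Back to a short-lived carbonyl-oxy group

The source may report more compounds than this note shows. Statements on the series, on what has been measured and on what is new or still open speak of the compounds shown alone.

In an ADME assay on cells (Hepatocyte, Homo sapiens) for metabolic stability (on this read-out higher numbers stand for a longer-lived compound and lower numbers for a shorter-lived compound), compound 3 (`CC(=O)NC1CCC(CN2CCN(c3cc(=O)c4cc(C(F)(F)F)cc([N+](=O)[O-])c4s3)CC2)CC1`) gives > 1.55 h as its entry, which is a limit of the assay and not a number. Compound 1 (`O=C(OC1CCC(CN2CCN(c3cc(=O)c4cc(C(F)(F)F)cc([N+](=O)[O-])c4s3)CC2)CC1)c1ccncc1`) gives 0.075 h as a measured number. Compound 2 (`O=C(OC1CCC(CN2CCN(c3cc(=O)c4cc(C(F)(F)F)cc([N+](=O)[O-])c4s3)CC2)CC1)c1ccc(C(F)(F)F)cc1`) gives 0.117 h as a measured number too. Compound 4 (`O=C(OC1CCC(CN2CCN(c3cc(=O)c4cc(C(F)(F)F)cc([N+](=O)[O-])c4s3)CC2)CC1)c1cccs1`) brings a carbonyl-oxy link back (((thiophen-2-yl)carbonyl)oxy in place of acetamido on a saturated ring carbon), with ((thiophen-2-yl)carbonyl)oxy in place of acetamido on a saturated ring carbon.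

Within the data shown here, two measured steps bear on this change. Swapping the aromatic ring on the carbonyl made little difference (a 1.6-fold higher number from compound 1 to compound 2 (0.19 log units; within the scatter)), so the thiophen-2-yl ring is expected to fit in with the other two rings. Acetamido in place of ((pyridin-4-yl)carbonyl)oxy was a large step (an at least 20-fold higher number from compound 1 to compound 3 (1.31 log units; beyond the scatter)), so the opposite kind of change is expected to give a large fall of similar size in this assay for this pair. The estimated fall is large (an at least 15-fold lower number from compound 3 to compound 4 (1.19 log units; beyond the scatter)). Compound 4 is expected at 0.1 h (range 0.05 h to 0.25 h).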

Compound 4, half-life: 0.0917 h
Compound 4: the middle estimate sits 1.1-fold (0.04 log units) above what was measured, within the range that was stated.
By their numbers in this assay, from the lowest: compounds 1, 4 and 2 (each within the scatter of the next). At a limit, above all of these: compound 3.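

In this assay, thiophen-2-yl now joins the two other aromatic rings on the carbonyl carbon with no ring standing apart: a 1.2-fold higher number from compound 1 to compound 4 (0.09 log units; within the scatter), and a 1.3-fold lower number from compound 2 to compound 4 (0.11 log units; within the scatter). A second comparison with acetamido on this saturated ring carbon, now with a different carbonyl-oxy group, also shows a large gap: an at least 16-fold lower number from compound 3 to compound 4 (1.22 log units; beyond the scatter). That gap is open-ended because compound 3 stands at a limit and not at a number: the limit of > 1.55 h in this assay, at which 1 of the 4 values shown sits.

Acetamido differs from the three carbonyl-oxy groups both in its link and in having no ring, so the compounds shown cannot tell which of these two differences goes with the longer-lived compound. A (thiophen-2-yl)carbonylamino group or a plain amine on the same ring carbon would help separate the two.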